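Swapping Benzylsulfanyl for Butylsulfanyl on a Shared Core

The source may hold more compounds than are shown below. What is called first, only, known or untested is meant among the compounds shown, and "the series" means these compounds.

Measured so far in a functional assay on the whole organism for activation, with Mus musculus as the target; on this read-out higher numbers stand for an effect only at larger amounts of compound and lower numbers for an effect already at smaller amounts:
- compound 1, `CCCCCOc1nc(N)c2nc(O)n(Cc3ccccc3)c2n1`: 0.3 mg/kg
- compound 2, `Nc1nc(SCc2ccccc2)nc2c1nc(O)n2Cc1ccccc1`: > 1 mg/kg
- compound 3, `CCCc1nc(N)c2nc(O)n(Cc3ccccc3)c2n1`: 3 mg/kg

Of the compounds shown here, three built on one shared core have been tested in this assay. Compound 1 gives 0.3 mg/kg. Compound 3 gives 3 mg/kg, and the step of a 10-fold higher number from compound 1 to compound 3 (1.00 log units; beyond the scatter) is beyond the scatter. For compound 2 the result is a limit of the assay, > 1 mg/kg, not a number. Because of the limit of > 1 mg/kg in this assay, at which 1 of the 3 values shown sits, the step of an at least 3.3-fold higher number from compound 1 to compound 2 (0.52 log units; beyond the scatter) can only be read as a bound, and the step that the limit leaves unreadable from compound 2 to compound 3 cannot be read at all.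

Compound 4, `CCCCSc1nc(N)c2nc(O)n(Cc3ccccc3)c2n1`, differs from compound 2 by propyl in place of phenyl on a saturated chain carbon bound to a sulfur. The measured steps show that the two chain groups, pentyloxy in compound 1 and propyl in compound 3, both give readable numbers, while the benzylsulfanyl group of compound 2 sits at the limit. Compound 4 carries a chain again, so it is expected to return to a readable value, estimated at 1 mg/kg with a range from 0.3 mg/kg to 3 mg/kg. The expected step is therefore a number no higher from compound 2 to compound 4 (the limit leaves the size open), though the limit on compound 2 keeps its size uncertain.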

Compound 4, minimum effective dose: 0.3 mg/kg
The estimate for compound 4 lay 3.3-fold (0.52 log units) above the measured number; low and high end bracket the measured number.
By their numbers in this assay, from the lowest: compounds 1 and 4 (each within the scatter of the next); then compound 3.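

Replacing the pentyloxy group with butylsulfanyl gives no change at the digits printed from compound 1 to compound 4 (within the scatter), while butylsulfanyl in place of propyl gives a 10-fold lower number from compound 3 to compound 4 (1.00 log units; beyond the scatter), so in this assay a chain attached through sulfur reads the same as one attached through oxygen, and the shorter propyl chain stands apart from both. On a saturated chain carbon bound to a sulfur, propyl in place of phenyl gives an at least 3.3-fold lower number from compound 2 to compound 4 (0.52 log units; beyond the scatter). That step is only a bound, because the result for compound 2 is a limit and not a number: the limit of > 1 mg/kg in this assay, at which 1 of the 4 values shown sits.

Where the true value of compound 2 lies remains open, and so does the full size of that step. Also open, on these data alone, is whether a longer chain such as hexylsulfanyl, or a butylsulfanyl chain carrying an amine, would keep the value of compound 4.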